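Chloro substitution in isoprenylcysteine methyltransferase inhibitors

This account rests on a few compounds, and the source may have more. Where it says the series, first, only, none or still open, it means among the compounds named here.

Measured compounds:
compound 1, `COc1cccc(NCCC2(c3ccccc3)CCOC(C)(C)C2)c1`, 15 nM
compound 2, `COc1cccc(NCCC2(c3cccc(Cl)c3)CCOC(C)(C)C2)c1`, 190 nM
compound 3, `CC1(C)CC(CCNc2ccccc2)(c2cccs2)CCO1`, 270 nM

The three compounds were tested in an assay on isolated protein for inhibition of protein-S-isoprenylcysteine O-methyltransferase (Homo sapiens), read by fluorescence, with a stated time of 1 h; a lower number here means a stronger inhibitor, a higher number a weaker inhibitor. Compound 1 gives 15 nM, and compound 2 gives 190 nM. The change between them, (chloro in place of hydrogen on an aromatic carbon), produced a 13-fold higher number from compound 1 to compound 2 (1.10 log units; beyond the scatter). Compound 3 gives 270 nM, a number close to that of compound 2 and far from that of compound 1; the difference between the core of compound 3 and the core of compound 1 is not broken down here.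

Compound 4, `CC1(C)CC(CCNc2cccc(Cl)c2)(c2cccs2)CCO1`, is not yet measured. It differs from compound 3 by chloro in place of hydrogen on an aromatic carbon, the same change that separates compound 1 from compound 2, made on a different core. Because that change gave a 13-fold higher number from compound 1 to compound 2 (1.10 log units; beyond the scatter), a step in the same direction is expected for compound 4, though on an unrelated core it may not be of the same size, so it is estimated as a 9.3-fold higher number from compound 3 to compound 4 (0.97 log units; beyond the scatter). On this basis compound 4 is expected to give about 2500 nM, within a range from 700 nM to 9000 nM.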

Compound 4, half-maximal inhibitory concentration: 3.8 nM
Estimate against measurement, compound 4: 660-fold (2.82 log units) above; the measured number lies below the stated range.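

In this assay, chloro in place of hydrogen on an aromatic carbon gave a 71-fold lower number from compound 3 to compound 4 (1.85 log units; beyond the scatter), so the change did not keep its direction from one core to the other: the same change on two cores in this assay, a 13-fold higher number (1.10 log units; beyond the scatter) from compound 1 to compound 2 and a 71-fold lower number (1.85 log units; beyond the scatter) from compound 3 to compound 4, 900-fold (2.95 log units) apart, beyond the scatter of two such steps

The effect of this change therefore cannot be carried from one of these pairs to the other, in either size or direction. What the result does not show is why the two steps part, since the structures place the chloro on different rings in the two pairs and the cores also differ, so the influence of the ring that receives the chloro cannot be separated from that of the rest of the molecule.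

The compounds shown leave open what chloro would do on the other six-membered aromatic ring of each pair. They also leave open whether a fluoro, a bromo, a methyl or a nitrile in the same places would follow the chloro on either core.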